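The source may report more compounds than this note shows. Statements on the series, on what has been measured and on what is new or still open speak of the compounds shown alone.

Compound 1: `O=C(COc1ccc(C(=O)/C=C/c2ccc(Cl)cc2Cl)cc1)N[C@H]1CCOC1=O` gives 26500 nM in a functional assay on MGC-803 cells (Homo sapiens) for antiproliferative activity, read by MTT assay, with a stated time of 72 h; on this read-out lower numbers stand for stronger inhibition and higher numbers for weaker inhibition.
Compound 2: `Cc1ccc(C(C)C)c(OCCSC(=S)N[C@H]2CCOC2=O)c1` gives 43400 nM in this assay.

Compound 1 stands at the lowest of the two numbers, though the gap to compound 2 lies within the scatter, so neither can be called the stronger. Compound 3, `O=C(COc1ccc(C(=O)/C=C/c2ccccc2)cc1)N[C@H]1CCOC1=O`, is not yet measured; it differs from compound 1 in one place: phenyl in place of 2,4-dichlorophenyl on a double-bonded chain carbon bound to a double-bonded chain carbon. For the measured compounds named here, no step between measured compounds shows what such a change does here. A small weakening is expected, a 1.5-fold higher number from compound 1 to compound 3 (0.18 log units; within the scatter), though it may stay within the scatter. Compound 3 is thus estimated at 40000 nM, with a range from 15000 nM to 110000 nM.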

Compound 3, half-maximal inhibitory concentration: > 64000 nM
Compound 3 ended at the assay's limit (the forecaster's own chance of this, stated with the estimate: 10%); middle value at least 1.6-fold (0.20 log units) away from the limit.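

In this assay, phenyl in place of 2,4-dichlorophenyl on a double-bonded chain carbon bound to a double-bonded chain carbon gives an at least 2.4-fold higher number from compound 1 to compound 3 (0.38 log units; beyond the scatter). For the compounds shown here, this is the first sign that this position responds to a change, and that losing the two chlorine atoms weakens inhibition. The reading for compound 3 is a limit of the assay and not a number, so the full size of the step stays unknown: the limit of > 64000 nM in this assay, at which 1 of the 3 values shown sits.

As far as these compounds go, whether one chlorine atom alone would suffice stays open. So does whether a different group here, such as methoxy or trifluoromethyl, would match 2,4-dichlorophenyl.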